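The source may report more compounds than this note shows. Statements on the series, on what has been measured and on what is new or still open speak of the compounds shown alone.

Measured so far in an ADME assay on S9 fraction from liver (Rattus norvegicus) for metabolic stability, read by LC-MS, using NADPH, with a stated time of 30 min; a higher number here means that more of the compound is left, a lower number that less of the compound is left:
compound 1 `CCCCCCCCc1ccc(OCC(=O)Cn2nnnc2-c2ccc(Cl)cc2)cc1`: 45%
compound 2 `CCCCCCCCc1ccc(OCC(=O)Cn2nnnc2-c2cccc(S(=O)(=O)N(C)C)c2)cc1`: 24%
compound 3 `CCCCCCCCc1ccc(OCC(=O)Cn2nnnc2-c2ccncc2)cc1`: 24%

Compound 3 stands at the low end of these numbers, and it shares that place with one other member of the set. That pair shows no change at the digits printed from compound 2 to compound 3 (within the scatter). Measured against the top of the set, the picture is a number 21 percentage points lower from compound 1 to compound 3 (beyond the scatter).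

The next member is compound 4 `CCCCCCCCc1ccc(OCC(=O)Cn2nnnc2-c2cccs2)cc1`. It carries thiophen-2-yl in place of pyridin-4-yl on an aromatic carbon of the five-membered aromatic ring with 4 nitrogen (thiophen-2-yl in place of pyridin-4-yl on an aromatic carbon). The rest of the molecule stays the same.

Within the data shown here, no measured step puts a thiophen-2-yl group at this place, so the evidence is indirect. Two steps exchange the group on this same carbon, a number 21 percentage points lower from compound 1 to compound 2 (beyond the scatter) and a number 21 percentage points lower from compound 1 to compound 3 (beyond the scatter), and both are modest. The third step, already noted, shows nothing beyond the scatter. A step larger than these modest ones is therefore not expected in this assay. A small rise is expected, with the result staying inside the span already seen and closer to its low end, where two of the three compounds lie.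

The expected change is a number 7 percentage points higher from compound 3 to compound 4 (within the scatter). For compound 4 the estimated value is 31%, with an expected range from 17% to 47%.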

Compound 4, percent of the compound remaining: 27%
For compound 4 the middle estimate is 4 percentage points above the measured one, within the range that was stated.
By their numbers in this assay, from the lowest: compounds 2, 3 and 4 (each within the scatter of the next); then compound 1.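

In this assay, the five-membered thiophen-2-yl ring on this aromatic carbon gives a number 3 percentage points higher from compound 3 to compound 4 (within the scatter) and a number 3 percentage points higher from compound 2 to compound 4 (within the scatter), so replacing either six-membered ring group with it does not move the result beyond the scatter. The new compound also keeps the separation from the 4-chlorophenyl group, with a number 18 percentage points lower from compound 1 to compound 4 (beyond the scatter), making compound 1 the only one of the four set apart, while pyridin-4-yl, 3-(dimethylsulfamoyl)phenyl and thiophen-2-yl cannot be told apart here. The data offer no measured explanation for this grouping.

The compounds shown leave open whether the separation of compound 1 depends on the chlorine atom or on the phenyl ring that carries it, a question that a plain phenyl, 4-fluorophenyl or 4-methoxyphenyl group on the same carbon would address. They also leave open whether this difference between groups would persist if a shorter alkyl chain, such as butyl, replaced the octyl chain on the shared core.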